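A few compounds are considered here, and "the series" means these few. Any claim that something is new, unique, unknown or untested is made for them only; others in the source may bear on it.

Measured compounds, read-out in a functional assay on cells (Platelet, Homo sapiens) for inhibition; a higher number here means a weaker inhibitor, a lower number a stronger inhibitor:
- compound 1 `CCOC(=O)c1ccc(-c2nn(Cc3ccccc3Cl)c3ccccc23)cc1`: 230 nM
- compound 2 `CCOC(=O)c1ccc(-c2nn(Cc3cccc(F)c3)c3ccccc23)cc1`: 270 nM
- compound 3 `CCOC(=O)c1ccc(-c2nn(Cc3ccncc3)c3ccccc23)cc1`: 5630 nM

Compound 2 stands second highest of the three numbers in this assay; its nearest neighbour is compound 1, from which the step of a 1.2-fold higher number from compound 1 to compound 2 (0.07 log units; within the scatter) is within the scatter, so the two cannot be ordered. Its furthest is compound 3, and the step of a 21-fold higher number from compound 2 to compound 3 (1.32 log units; beyond the scatter) is a large loss of potency when the benzyl-type group is exchanged for a pyridin-4-yl-bearing one. The parallel step a 24-fold higher number from compound 1 to compound 3 (1.39 log units; beyond the scatter) points the same way.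

Compound 4 `CCOC(=O)c1ccc(-c2nn(C(C)C)c3ccccc23)cc1` is not yet measured. The change from compound 2 is isopropyl in place of 3-fluorobenzyl on an aromatic nitrogen. Within the data shown here, the only steps that touch this position are those above: swapping one six-membered carbon ring for another with a different halogen leaves the number essentially unchanged, whereas replacing it with a nitrogen-containing ring costs a great deal. Among the measured compounds shown here, no measured compound lacks a ring at this position, so the step to isopropyl has no direct precedent. Given the sensitivity shown by compound 3 in a 21-fold higher number from compound 2 to compound 3 (1.32 log units; beyond the scatter), compound 4 is expected to show a weaker inhibition than compound 2, by a step estimated at a 5.6-fold higher number from compound 2 to compound 4 (0.74 log units; beyond the scatter), though with wide uncertainty. Compound 4 is estimated at 1500 nM, with a range from 400 nM to 6000 nM.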

Compound 4, half-maximal inhibitory concentration: 650 nM
The estimate for compound 4 lay 2.3-fold (0.36 log units) above the measured number; low and high end bracket the measured number.
By their numbers in this assay, from the lowest: compounds 1 and 2 (each within the scatter of the next); then compound 4; then compound 3.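

Working notes on the group on the aromatic nitrogen, read in this assay: an aromatic ring on this substituent is not required for inhibition, since isopropyl, which has no ring, costs only a modest amount in both comparisons, a 2.4-fold higher number from compound 2 to compound 4 (0.38 log units; beyond the scatter) and a 2.8-fold higher number from compound 1 to compound 4 (0.45 log units; beyond the scatter). The large loss seen earlier with (pyridin-4-yl)methyl therefore cannot be read as the loss of a carbon-only aromatic ring alone, as the step of an 8.7-fold lower number from compound 3 to compound 4 (0.94 log units; beyond the scatter) shows that isopropyl, with no ring at all, stands clearly better than that nitrogen-containing group. Among the four compounds, the position now reads as a graded order: 2-chlorobenzyl and 3-fluorobenzyl, which cannot be separated from each other, then isopropyl, then (pyridin-4-yl)methyl.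

Nothing at hand explains this order of groups. The compounds shown leave open how a saturated ring such as cyclohexylmethyl, a longer chain such as n-butyl, or an unsubstituted benzyl would fall in this order, and whether a carboxylic acid in place of the ethyl ester would keep the same ranking at this position.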